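Chloro in place of ethoxy: the step to compound 4

The compounds below may be only part of what the source reports. "The series", "measured", "known", "first", "only" and "open" are said of these compounds alone.

In a functional assay on KB cells (Homo sapiens) for inhibition (a lower number here means a stronger inhibitor, a higher number a weaker inhibitor), compound 1 (`CC(=O)OC1C(CBr)OC(n2c(Cl)nc3cc(Cl)c(Cl)cc32)C1OC(C)=O`) gives 60000 nM and compound 2 (`CC(=O)OC1C(CN=[N+]=[N-])OC(n2c(Cl)nc3cc(Cl)c(Cl)cc32)C1OC(C)=O`) gives 70000 nM on the same read-out. Compound 3 (`CCOC[C@H]1OC(n2c(Cl)nc3cc(Cl)c(Cl)cc32)[C@H](O)[C@@H]1O`) gives 80000 nM and so stands within the scatter of both other compounds, with nothing separating the three. Still open, going by these compounds, is compound 4 (`O[C@@H]1[C@@H](CCl)OC(n2c(Cl)nc3cc(Cl)c(Cl)cc32)[C@@H]1O`), which has no value yet. The change is chloro in place of ethoxy on a saturated chain carbon bound to a saturated ring carbon and reads as chloro in place of ethoxy on a saturated chain carbon bound to a saturated ring carbon, or ethoxymethyl to chloromethyl when cut one bond further out.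

For the measured compounds named here, the one measured step at that place is a 1.2-fold higher number from compound 1 to compound 2 (0.07 log units; within the scatter) and it exchanges azido for bromo, so it stays small. Going by the values given here, no measured pair tests ethoxy or chloro at that place, which makes this step indirect evidence only. Among the compounds with values here, with a 1.2-fold higher number from compound 1 to compound 2 (0.07 log units; within the scatter) as the sole guide, no change beyond the scatter is expected in either direction. The expected size is a 1.3-fold lower number from compound 3 to compound 4 (0.12 log units; within the scatter) on the present estimate. For compound 4 the estimated value in this assay is 60000 nM with an expected range from 25000 nM to 130000 nM at this stage.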

Compound 4, half-maximal inhibitory concentration: 90000 nM
The estimate for compound 4 lay 1.5-fold (0.18 log units) below the measured number, within the range that was stated.
By their numbers in this assay, from the lowest: compounds 1, 2, 3 and 4 (each within the scatter of the next).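

In this assay, the exchange on a saturated chain carbon bound to a saturated ring carbon stays within the scatter (a 1.1-fold higher number from compound 3 to compound 4 (0.05 log units; within the scatter)), although ethoxy, with 3 heavy atoms and 1 hydrogen-bond acceptor, gives way to chloro, with 1 heavy atom and 0 hydrogen-bond acceptors. For the compounds shown here, this is the first measured pair that involves ethoxy or chloro at this position, and it adds a second exchange there to the azido-for-bromo step (a 1.2-fold higher number from compound 1 to compound 2 (0.07 log units; within the scatter)), which also stays within the scatter. No measurement shown here gives any explanation for these flat readings.

Still open, going by these compounds, is whether an amine, a carboxylic acid or a longer chain on that same chain carbon would move the number beyond the scatter. With neither measured step at this position exceeding the scatter, the compounds shown do not yet reveal which kinds of group at this position, if any, change the reading in this assay.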